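The source may hold more compounds than are shown below. What is called first, only, known or untested is meant among the compounds shown, and "the series" means these compounds.

In a functional assay on LOX IMVI cells (Homo sapiens) for inhibition, read by colorimetric assay and sulforhodamine B assay, with a stated time of 48 h (on this read-out lower numbers stand for stronger inhibition of growth and higher numbers for weaker inhibition of growth), compound 1 `CCCCCCCCCCCC[C@@H](O)[C@H]1CC[C@H]([C@H](O)CCCCCCCCCCNC(=O)c2cccs2)O1` gives 1290 nM and compound 2 `CCCCCCCCCCCC[C@@H](O)[C@H]1CC[C@H]([C@H](O)CCCCCCCCCCNC(=O)c2ccoc2)O1` gives 21900 nM, while compound 3 `CCCCCCCCCCCC[C@@H](O)[C@H]1CC[C@H]([C@H](O)CCCCCCCCCCNC(=O)c2cncs2)O1` gives 100000 nM, the highest of the three numbers. Compound 4 `CCCCCCCCCCCC[C@@H](O)[C@H]1CC[C@H]([C@H](O)CCCCCCCCCCNC(=O)c2ccsc2)O1` is unmeasured and differs from compound 3 as follows: thiophen-3-yl in place of 1,3-thiazol-5-yl on a carbonyl carbon. Its thiophen-3-yl is a thiophene like the thiophen-2-yl of compound 1, so the closest evidence is a 78-fold higher number from compound 1 to compound 3 (1.89 log units; beyond the scatter). Also relevant are a 4.6-fold higher number from compound 2 to compound 3 (0.66 log units; beyond the scatter) and a 17-fold higher number from compound 1 to compound 2 (1.23 log units; beyond the scatter), which show how far two of these groups can differ. A large step to a lower number is therefore expected in this assay, and the expected step reads a 22-fold lower number from compound 3 to compound 4 (1.35 log units; beyond the scatter). For compound 4 the estimated value is 4500 nM, with an expected range of 1000 nM to 22000 nM.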

Compound 4, concentration for 50% growth inhibition: 1510 nM
The estimate for compound 4 lay 3.0-fold (0.47 log units) above the measured number; measured number inside the range.
By their numbers in this assay, from the lowest: compounds 1 and 4 (each within the scatter of the next); then compound 2; then compound 3.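

Swapping thiophen-2-yl for thiophen-3-yl on the carbonyl carbon gives a 1.2-fold higher number from compound 1 to compound 4 (0.07 log units; within the scatter) and so does not separate the two thiophene attachments. Thiophen-3-yl, by contrast, gives a 15-fold lower number from compound 2 to compound 4 (1.16 log units; beyond the scatter) in place of furan-3-yl and a 66-fold lower number from compound 3 to compound 4 (1.82 log units; beyond the scatter) in place of 1,3-thiazol-5-yl, so among these four compounds the two thiophene amides stand apart from the other two. No available evidence accounts for this difference. Still open, going by these compounds, is whether a phenyl or pyridin-3-yl ring on the carbonyl carbon would match the thiophenes, and whether a shorter chain before the amide nitrogen would preserve their values.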